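Chloro to Fluoro on the Benzyl Ring of a Thiazolidinedione

This account rests on a few compounds, and the source may have more. Where it says the series, first, only, none or still open, it means among the compounds named here.

Compound 3 `C=C(Br)C(=O)Nc1ccc(/C=C2\SC(=O)N(Cc3cccc(Cl)c3)C2=O)cc1` is the strongest inhibitor of the three measured compounds. In a functional assay on CCRF-CEM cells (Homo sapiens) for cytotoxicity, read by cell counting, with a stated time of 3 days (a higher number here means a weaker inhibitor, a lower number a stronger inhibitor), compound 3 gives 3700 nM. Compound 2 `Nc1ccc(/C=C2\SC(=O)N(Cc3ccc(Cl)cc3)C2=O)cc1` gives 87000 nM, and compound 1 `Nc1ccc(/C=C2\SC(=O)N(Cc3ccc(F)cc3)C2=O)cc1` gives 111000 nM. The difference between the cores of compound 3 and compound 2 is not broken down here. The change from compound 2 to compound 1, (fluoro in place of chloro on an aromatic carbon), gave a 1.3-fold higher number from compound 2 to compound 1 (0.11 log units; within the scatter). Compound 4 `C=C(Br)C(=O)Nc1ccc(/C=C2\SC(=O)N(Cc3cccc(F)c3)C2=O)cc1` carries the same kind of change relative to compound 3, (fluoro in place of chloro on an aromatic carbon), though here the place is meta to a large group rather than para. The expectation for compound 4 rests on the step of a 1.3-fold higher number from compound 2 to compound 1 (0.11 log units; within the scatter), which stayed within the scatter. Compound 4 is therefore expected to give 4000 nM, between 2000 nM and 8000 nM. This amounts to an estimated step of a 1.1-fold higher number from compound 3 to compound 4 (0.03 log units; within the scatter).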

Compound 4, half-maximal inhibitory concentration: 3200 nM
Compound 4: middle estimate off by 1.3-fold (0.10 log units), on the high side, and the stated range covers the measured number.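

In this assay, fluoro in place of chloro on the benzyl ring gave a 1.2-fold lower number from compound 3 to compound 4 (0.06 log units; within the scatter), so compound 3 and compound 4 cannot be told apart. The same change on the two cores gave steps that agree: the same change on two cores in this assay, a 1.3-fold higher number (0.11 log units; within the scatter) from compound 2 to compound 1 and a 1.2-fold lower number (0.06 log units; within the scatter) from compound 3 to compound 4, 1.5-fold (0.17 log units) apart, within the scatter of two such steps. This shows that the exchange carried over between these two cores with no readable effect in this cell assay, but two pairs do not show that it would hold on other cores, and they give no cause.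

The compounds shown leave open how a hydrogen, a methyl or a methoxy group would read in place of the halogen. They also leave open how bromine at that place would compare.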